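The source may report more compounds than this note shows. Statements on the series, on what has been measured and on what is new or still open speak of the compounds shown alone.

In an ADME assay on HEK293 cells (Homo sapiens) for cytotoxicity, read by CCK-8 assay, with a stated time of 48 h (a lower number here means a stronger inhibitor, a higher number a weaker inhibitor), compound 1 (`COc1ccc(/C=C\c2cc(OC)c(OC)c(OC)c2)cc1OCc1ccc(CN2CC[C@H](C(=O)O)C2)cc1`) reads > 50000 nM, which is a limit of the assay and not a number. Compound 2 (`COc1ccc(/C=C\c2cc(OC)c(OC)c(OC)c2)cc1OCc1ccc(CNCCNC(C)=O)cc1`) reads > 50000 nM, which is likewise a limit. Compound 2 therefore has no exact position on the scale, and the record so far is the limit of > 50000 nM in this assay, at which 2 of the 2 values shown sit.

Compound 3 (`COc1ccc(/C=C\c2cc(OC)c(OC)c(OC)c2)cc1OCc1ccc(CN2CC[C@@H](C(=O)O)C2)cc1`) keeps the shared core and changes in one place, on a saturated chain carbon bound to an aromatic carbon: 3-carboxypyrrolidin-1-yl in place of (2-acetamidoethyl)amino on a saturated chain carbon bound to an aromatic carbon. In words, 3-carboxypyrrolidin-1-yl takes the place of (2-acetamidoethyl)amino.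

Among the measured compounds shown here, the one measured step that bears on this change is a step that the two limits leave unreadable from compound 1 to compound 2, which exchanges the same two named groups in the opposite direction. It offers no size to carry over, so no step beyond the usual scatter is expected in this assay, and no direction can be assigned. The expected step is a number no higher from compound 2 to compound 3 (the limit leaves the size open). For compound 3 the estimated value is 50000 nM, with an expected range of 25000 nM to 100000 nM, and the result will most likely be reported only as a limit.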

Compound 3, half-maximal inhibitory concentration: 27000 nM
Estimate against measurement, compound 3: 1.9-fold (0.27 log units) above, and the stated range covers the measured number.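

In this assay, among the compounds shown here, compound 3 gives the first exact number for a group at this place, on a saturated chain carbon bound to an aromatic carbon, where the record had held only a limit of the assay: the limit of > 50000 nM in this assay, at which 2 of the 3 values shown sit. Putting 3-carboxypyrrolidin-1-yl in place of (2-acetamidoethyl)amino now has a readable bound, an at least 1.8-fold lower number from compound 2 to compound 3 (0.26 log units; that floor lies within the scatter), so the exchange that could not be sized before has a floor, though not one that clears the usual scatter. The same group with the other drawn configuration gives an at least 1.8-fold lower number from compound 1 to compound 3 (0.26 log units; that floor lies within the scatter), a step that rests on a single structural difference: the fact that compounds 1 and 3 differ only in the configuration as drawn.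

Going by these compounds, the step between compounds 1 and 2 cannot be read, and the true sizes of the two new steps stay open, since each has a limit at one end. Also open, on these data alone, is whether a methyl ester in place of the carboxylic acid, or a six-membered piperidine in place of the pyrrolidine, would give an exact number in this assay, and whether either configuration would then matter beyond the scatter.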